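From compound 3 to its R form, compound 4

A few compounds are considered here, and "the series" means these few. Any claim that something is new, unique, unknown or untested is made for them only; others in the source may bear on it.

In a physicochemical assay for lipophilicity, at pH 7.4 (on this read-out lower numbers stand for lower lipophilicity and higher numbers for higher lipophilicity), compound 3 (`CC(C(=O)O)c1nn(Cc2cn3cc(OCC4CC4)c(Cl)cc3n2)c2ccccc2c1=O`) gives 2.44. Compound 2 (`O=C(O)Cn1nc(Cc2nc3cc(Cl)c(OC(F)(F)F)cc3[nH]2)c2ccccc2c1=O`) gives 2.54, within the scatter of compound 3. Compound 1 (`CCOc1cc2[nH]c(Cc3nn(CC(=O)N4CCOCC4)c(=O)c4ccccc34)nc2cc1Cl`) gives 3.32, which is higher than compound 3 and beyond the scatter. Within the data shown here, no two measured compounds differ in one place, so the series offers no measured step to draw on.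

The next compound is compound 4 (`C[C@@H](C(=O)O)c1nn(Cc2cn3cc(OCC4CC4)c(Cl)cc3n2)c2ccccc2c1=O`). Its difference from compound 3 is this: the two compounds have the same atoms and bonds; at least one stereo element is drawn with a configuration in one of them and without one in the other: 1 of 1 stereo elements differ; a stereocentre at a saturated chain carbon is drawn without a configuration in compound 3 and R in compound 4. The two compounds have the same atoms and bonds, and a stereocentre at a saturated chain carbon is drawn without a configuration in compound 3 and R in compound 4.

In this assay, no step beyond the scatter is expected, and neither direction is favoured. The expectation therefore stays close to compound 3 at 2.44. The expected result is no change at the digits printed from compound 3 to compound 4 (within the scatter), within the scatter. The estimate for compound 4 is 2.44, with an expected range from 2.14 to 2.74.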

Compound 4, distribution coefficient: 2.41
Beside the measured number, compound 4's estimate is 0.03 log units above it; the range from low to high includes it.
By their numbers in this assay, from the lowest: compounds 4, 3 and 2 (each within the scatter of the next); then compound 1.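

In this assay, among these compounds, the series now has its only measured step between compounds that differ in one place, and it reads a number 0.03 log units lower from compound 3 to compound 4 (within the scatter). Among the compounds shown here, compounds 1, 2 and 3 offered no such pair, so this is the first direct reading at the saturated chain carbon, and drawing it as R leaves compound 4 level with compound 3. The data do not state what compound 3 contains at this carbon, so the reading rests on a single difference in how the two are drawn: the fact that one of compounds 3 and 4 is drawn with a defined configuration and the other without, at the place where they differ

On these data alone, the S form at this carbon remains open, so no comparison between the two defined configurations is possible. Also open, as far as these compounds go, is whether the same picture holds with a longer chain on this carbon, or with a tetrazole in place of the carboxylic acid.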